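Ethoxy to isopropoxy in a sparsely measured series

A few compounds are considered here, and "the series" means these few. Any claim that something is new, unique, unknown or untested is made for them only; others in the source may bear on it.

Going by the values given here, in a functional assay on MCF7 cells (Homo sapiens) for inhibition, read by MTT assay, with a stated time of 72 h (on this read-out higher numbers stand for weaker inhibition and lower numbers for stronger inhibition), compound 1 `O=C1C=C[C@@H](OC2CCCC2)O[C@@H]1CO` gives 20700 nM as the only number so far. Compound 2 `CCO[C@@H]1C=CC(=O)[C@@H](CO)O1` has no number to stand on: its result reads "not determined" (no result reported) and gives no anchor. Compound 3 `CC(C)O[C@@H]1C=CC(=O)[C@@H](CO)O1` differs from compound 2 by methyl in place of hydrogen on a saturated chain carbon bound to an oxygen on a saturated carbon and a saturated chain carbon with ethoxy becoming isopropoxy. Among the compounds with values here, no measured step covers this change, so the expectation in this assay is a shift of no size beyond the scatter and in no set direction, with compound 1 at 20700 nM as the sole guide. Compound 3 is estimated at 22000 nM with an expected range from 7000 nM to 60000 nM for now.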

Compound 3, half-maximal inhibitory concentration: 36000 nM
The estimate for compound 3 lay 1.6-fold (0.21 log units) below the measured number, within the range that was stated.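

In this assay, isopropyl in place of cyclopentyl on an oxygen on a saturated carbon gives a 1.7-fold higher number from compound 1 to compound 3 (0.24 log units; within the scatter) and so does not separate the two groups. The ethoxy to isopropoxy change itself cannot be read, as compound 2 still has no number. Nothing available explains this result.

As far as these compounds go, whether a longer chain, an amine or a carboxylic acid in this place would move the number beyond the scatter stays open. The compounds shown also leave open whether any group here matters in this cell read-out.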